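Methyl for Fluoro, Read Across Two Cores

The source may hold more compounds than are shown below. What is called first, only, known or untested is meant among the compounds shown, and "the series" means these compounds.

Measured so far:
compound 1, `COc1cc(C(=O)c2sc(Nc3ccc(F)cc3)nc2N)cc(OC)c1OC`: 900 nM
compound 2, `COc1cc(C(=O)c2sc(Nc3ccc(C)cc3)nc2N)cc(OC)c1OC`: 31 nM
compound 3, `Nc1nc(Nc2ccc(F)cc2)sc1C(=O)c1ccccc1`: > 10000 nM

In a functional assay on L1210 cells (Mus musculus) for antiproliferative activity, read by cell counting, with a stated time of 2 days (on this read-out higher numbers stand for weaker inhibition and lower numbers for stronger inhibition), compound 1 gives 900 nM, and compound 2 gives 31 nM. The change between them, (methyl in place of fluoro on an aromatic carbon), produced a 29-fold lower number from compound 1 to compound 2 (1.46 log units; beyond the scatter). For compound 3, this assay reports only a limit, > 10000 nM, which is the limit of > 10000 nM in this assay, at which 1 of the 3 values shown sits. How the core of compound 3 differs from the core of compound 1 is not broken down here.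

Compound 4, `Cc1ccc(Nc2nc(N)c(C(=O)c3ccccc3)s2)cc1`, has not yet been measured in this assay. It differs from compound 3 by methyl in place of fluoro on an aromatic carbon, the same change seen from compound 1 to compound 2, at a place described in the same words. The step expected for compound 4 in this assay is an at least 3.3-fold lower number from compound 3 to compound 4 (0.52 log units; beyond the scatter). That expectation rests on a 29-fold lower number from compound 1 to compound 2 (1.46 log units; beyond the scatter), while the limit for compound 3 leaves its starting point open. Compound 4 is estimated at 3000 nM, between 600 nM and 15000 nM.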

Compound 4, half-maximal inhibitory concentration: 2800 nM
The estimate for compound 4 lay 1.1-fold (0.03 log units) above the measured number; the range from low to high includes it.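

In this assay, the change from 4-fluorophenyl to 4-methylphenyl again goes with a lower number on the second core, an at least 3.5-fold lower number from compound 3 to compound 4 (0.55 log units; beyond the scatter). The direction of the step carries over from one core to the other, but whether its size carries over is not settled: the same change on two cores in this assay, a 29-fold lower number (1.46 log units; beyond the scatter) from compound 1 to compound 2 and an at least 3.5-fold lower number (0.55 log units; beyond the scatter) from compound 3 to compound 4; the limit leaves it open whether they differ. Compound 3 gives > 10000 nM, which is a limit of the assay and not a number, so the step on this core is a bound and not a measured size: the limit of > 10000 nM in this assay, at which 1 of the 4 values shown sits.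

With only fluoro and methyl at this place, the compounds shown leave open how a chloro group, a methoxy group or an amine there would read on either core. On these data alone, whether the change holds on any further core also stays open.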